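A few compounds are considered here, and "the series" means these few. Any claim that something is new, unique, unknown or untested is made for them only; others in the source may bear on it.

The three measured compounds share one core and differ only in the five-membered aromatic ring attached to it. Compound 1 `c1ccc(-c2cnco2)c(NCC2=NCCN2)c1` gives 17.4 nM in a functional assay for activation of Alpha-1A adrenergic receptor (Homo sapiens), read by calcium flux; on this read-out higher numbers stand for an effect only at larger amounts of compound and lower numbers for an effect already at smaller amounts. Compound 2 `Cc1nc(-c2ccccc2NCC2=NCCN2)cs1` gives 4.47 nM in this assay, and compound 3 `c1csc(-c2ccccc2NCC2=NCCN2)c1` gives 2.24 nM in this assay. Among these numbers compound 2 holds the second highest value: its nearest neighbour is compound 3, reached by a 2.0-fold lower number from compound 2 to compound 3 (0.30 log units; within the scatter), and its furthest is compound 1, separated by a 3.9-fold lower number from compound 1 to compound 2 (0.59 log units; beyond the scatter).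

Compound 4 `Cc1nc(-c2ccccc2NCC2=NCCN2)co1` has not yet been measured. It differs from compound 2 by 2-methyl-1,3-oxazol-4-yl in place of 2-methyl-1,3-thiazol-4-yl on an aromatic carbon. The measured step that bears most on this change is a 3.9-fold lower number from compound 1 to compound 2 (0.59 log units; beyond the scatter), in which a ring with oxygen gave way to a ring with sulfur and the number fell. The step of a 7.8-fold lower number from compound 1 to compound 3 (0.89 log units; beyond the scatter) points the same way with a sulfur-containing ring. Reversing that exchange, sulfur for oxygen, in compound 4 is therefore expected to move the number upward in this assay, though the oxygen ring of compound 1 is not the same group as that of compound 4, so the size is uncertain. Compound 4 is estimated at 11 nM, with a range from 4.5 nM to 28 nM. For compound 4 this is expected to mean a 2.5-fold higher number from compound 2 to compound 4 (0.39 log units; beyond the scatter).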

Compound 4, half-maximal effective concentration: 324 nM
Compound 4: the middle estimate sits 29-fold (1.47 log units) below what was measured, outside the stated range (above it).
By their numbers in this assay, from the lowest: compounds 3 and 2 (each within the scatter of the next); then compound 1; then compound 4.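

In this assay, among these compounds, the exchange of sulfur for oxygen in an otherwise matching 2-methyl ring, on an aromatic carbon of the six-membered ring, gives a 72-fold higher number from compound 2 to compound 4 (1.86 log units; beyond the scatter) and so shows that this single ring atom can carry a large step, larger than any step among the earlier compounds. The oxygen rings are not interchangeable at this position either, since 2-methyl-1,3-oxazol-4-yl in place of 1,3-oxazol-5-yl gives a 19-fold higher number from compound 1 to compound 4 (1.27 log units; beyond the scatter) and the step against the thiophen-2-yl ring is wider still, at a 140-fold higher number from compound 3 to compound 4 (2.16 log units; beyond the scatter) for the same place on the shared core. The leaving and entering groups match in heavy-atom count, hydrogen-bond donors, hydrogen-bond acceptors and net charge, so none of these counts separates compound 2 from compound 4.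

Nothing shown here explains why this exchange carries so large a step. Going by these compounds, it also remains open whether the gap between the sulfur ring and the oxygen ring would persist if an amine or a longer chain such as ethyl stood in place of the methyl group on these rings.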